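Phenyl on the Ring Amide Nitrogen of Compound 1

The source may hold more compounds than are shown below. What is called first, only, known or untested is meant among the compounds shown, and "the series" means these compounds.

Of the compounds shown here, three have been measured in a functional assay on A549 cells (Homo sapiens) for antiproliferative activity, read by MTT assay, with a stated time of 72 h; on this read-out higher numbers stand for weaker inhibition and lower numbers for stronger inhibition. Compound 1 `COc1ncc(-c2ccc3c(c2)NC(=O)CO3)cc1NS(=O)(=O)c1ccc(F)cc1` gives 8070 nM, the lowest number among them. Compound 2 `COc1ccc(N2C(=O)COc3ccc(-c4cnc(Cl)c(NS(=O)(=O)c5ccc(F)cc5)c4)cc32)cc1` gives 30400 nM, a gap to compound 1 that lies beyond the scatter, although the two differ in more than one place. For compound 3 `COc1cccc(N2C(=O)COc3ccc(-c4cnc5ccccc5c4)cc32)c1` the assay reports only a limit, > 40000 nM.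

Compound 4 `COc1ncc(-c2ccc3c(c2)N(c2ccccc2)C(=O)CO3)cc1NS(=O)(=O)c1ccc(F)cc1` departs from compound 1 in a single place: phenyl in place of hydrogen on an amide-type nitrogen in a ring. In words, it has phenyl in place of hydrogen on an amide-type nitrogen in a ring. Within the data shown here, no pair of measured compounds isolates this change, so the expectation rests on indirect comparison. The nearest guide is compound 2, which bears a substituted phenyl on that nitrogen and gives 30400 nM, though it also differs elsewhere. Compound 3 bears a substituted phenyl there too and gave no number. In this assay a moderate move toward a higher number is therefore expected, of a size slightly beyond the scatter. The expected step is a 2.2-fold higher number from compound 1 to compound 4 (0.35 log units; beyond the scatter). Compound 4 is estimated at 18000 nM, with an expected range from 6000 nM to 40000 nM.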

Compound 4, half-maximal inhibitory concentration: 3490 nM
Estimate against measurement, compound 4: 5.2-fold (0.71 log units) above; measured number outside the range, below it.
By their numbers in this assay, from the lowest: compound 4; then compound 1; then compound 2. At a limit, above all of these: compound 3.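

In this assay, among these compounds, this pair isolates the position for the first time: phenyl in place of hydrogen on the amide-type nitrogen gives a 2.3-fold lower number from compound 1 to compound 4 (0.36 log units; beyond the scatter), a modest step beyond the scatter. The amide hydrogen is therefore not required for activity in this pair, and the nitrogen carries an unsubstituted phenyl with no loss on this read-out, something compounds 2 and 3 could not show, as each bears a substituted phenyl there and differs from compound 1 in other places as well. Nothing among the data shown accounts for the size or direction of this step.

The compounds shown leave open whether the phenyl ring itself matters on this nitrogen, or whether a methyl, a benzyl or a longer chain ending in an amine would move the number in the same direction. They also leave open whether the same change would give a similar step on a core that differs elsewhere from that of compound 1.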